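The source may hold more compounds than are shown below. What is called first, only, known or untested is meant among the compounds shown, and "the series" means these compounds.

In a physicochemical assay for solubility, read by LC-MS, in phosphate buffer, measured as thermodynamic solubility, with a stated time of 24 h, at pH 7.4 (a higher number here means a more soluble compound, a lower number a less soluble compound), three compounds have been measured:

compound 1, `Cn1cc(-c2cnc3[nH]cc(-c4cccc(F)c4)c3c2)cn1`, gives 3000 nM;
compound 2, `Cn1cc(-c2cnc3[nH]cc(-c4ccc(F)c(F)c4)c3c2)cn1`, gives 5000 nM;
compound 3, `Cn1cc(-c2cnc3[nH]cc(-c4cccc([N+](=O)[O-])c4)c3c2)cn1`, gives 2000 nM.

All three values lie within the scatter of one another, so compound 1 cannot be ranked against the others: its nearest neighbour is compound 3, reached by a 1.5-fold lower number from compound 1 to compound 3 (0.18 log units; within the scatter), and its furthest is compound 2, reached by a 1.7-fold higher number from compound 1 to compound 2 (0.22 log units; within the scatter).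

Compound 4, `Cn1cc(-c2cnc3[nH]cc(C4CCNC4)c3c2)cn1`, differs from compound 1 in one place: pyrrolidin-3-yl in place of 3-fluorophenyl on an aromatic carbon. For the measured compounds named here, both measured steps keep the aromatic ring and exchange only one group on it, and both stay within the scatter; no measured step replaces the whole 3-fluorophenyl with pyrrolidin-3-yl, so they give little guidance. The expectation for compound 4 is nevertheless a higher number, a 6.7-fold higher number from compound 1 to compound 4 (0.82 log units; beyond the scatter), with wide uncertainty. Compound 4 is estimated at 20000 nM, in the range 5000 nM to 80000 nM.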

Compound 4, solubility: 1000000 nM
The estimate for compound 4 lay 50-fold (1.70 log units) below the measured number, outside the stated range (above it).
By their numbers in this assay, from the lowest: compounds 3, 1 and 2 (each within the scatter of the next, the first and the last beyond it); then compound 4.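

The earlier exchanges, made on the aromatic ring of the 3-fluorophenyl group, all stayed within the scatter, so they gave no sign of how much this position could matter. Replacing that whole group with pyrrolidin-3-yl on the same aromatic carbon gives a far larger change in this assay (a 330-fold higher number from compound 1 to compound 4 (2.52 log units; beyond the scatter)), so the group held here can move the number strongly. Nothing measured here explains the size of this step.

The compounds shown leave open whether the nitrogen of pyrrolidin-3-yl or the loss of the aromatic ring counts for more, since both change together. A cyclopentyl group or an open-chain amine at this position would help separate the two.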